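The source may report more compounds than this note shows. Statements on the series, on what has been measured and on what is new or still open speak of the compounds shown alone.

Working notes on the series. Compound 1 `COc1ccc(-c2cc(=O)c3c(OC)cc(OC)cc3n2S(=O)(=O)c2cc(F)c(F)c(F)c2)cc1` and compound 2 `COc1ccc(-c2cc(=O)c3c(OC)cc(OC)cc3n2S(=O)(=O)c2ccc(Br)s2)cc1` share the core of the set, but in a functional assay on SEM cells (Homo sapiens) for antiproliferative activity, with a stated time of 72 h (a lower number here means that less compound is needed, a higher number that more compound is needed for the effect), compound 1 gives "not determined" (no result reported) and compound 2 gives "not determined" (no result reported), so no result for either was reported. For the measured compounds named here, compound 3 `COc1cc(OC)c2c(=O)cc(C(=O)Nc3ccc(Oc4ccc([N+](=O)[O-])cc4)cc3)[nH]c2c1` is the only member with a number: in this assay compound 3 gives 480 nM, so it stands alone and no step between measured compounds can be drawn from it. Compound 4 `COc1cc(OC)c2c(=O)cc(C(=O)Nc3ccc(-n4cccc4)cc3)[nH]c2c1` differs from compound 3 in one place: 1H-pyrrol-1-yl in place of 4-nitrophenoxy on an aromatic carbon. With no measured step of this kind in the set, the expected change is a modest loss, the estimated step being a 1.9-fold higher number from compound 3 to compound 4 (0.27 log units; within the scatter), which may still fall within the usual scatter. For compound 4 the estimate in this assay is 900 nM, with a range from 300 nM to 3000 nM.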

Compound 4, half-maximal effective concentration: > 77000 nM
Compound 4 ended at the assay's limit; the forecaster's own chance of this, stated with the estimate: 10%; middle value at least 85-fold (1.93 log units) from the limit.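

This position, on an aromatic carbon para to a large group, now has its first measured step: in this assay, 1H-pyrrol-1-yl in place of 4-nitrophenoxy gives an at least 160-fold higher number from compound 3 to compound 4 (2.20 log units; beyond the scatter). Compound 4 sits at a limit of the assay, not at a number: the limit of > 77000 nM in this assay, at which 1 of the 4 values shown sits. The group at this position is therefore not interchangeable in this assay, at least across these two groups.

Going by these compounds, how a plain phenoxy group or an amine would behave at this position stays open. So does which part of 4-nitrophenoxy carries the difference, and steps involving compound 1 or compound 2 cannot be read.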